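A few compounds are considered here, and "the series" means these few. Any claim that something is new, unique, unknown or untested is made for them only; others in the source may bear on it.

Compound 1 `Cc1ccc2c(NCc3ccc(NC(=O)C4CCN(Cc5ccccc5)CC4)cc3)nc(N3CCCCCC3)nc2c1`: in a functional assay on SV5A8 cells (Homo sapiens) for cytotoxicity (on this read-out lower numbers stand for stronger inhibition and higher numbers for weaker inhibition), compound 1 reaches only the assay limit > 6880 nM.
Compound 2 `Cc1ccc2c(NCc3ccc(NC(=O)C4CCN(Cc5ccccc5)CC4)cc3)nc(N3CCN[C@@H](C)C3)nc2c1`: in this assay compound 2 likewise gives only the assay limit > 8860 nM.
Compound 3 `Cc1ccc2c(NCc3ccc(NC(=O)C4CCN(CC5CCNCC5)CC4)cc3)nc(N(C)C)nc2c1`: in this assay compound 3 also gives only the assay limit > 8070 nM.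

All three measured compounds sit at a limit rather than at a number, as the limit of > 6880 nM in this assay, at which 1 of the 3 values shown sits, the limit of > 8070 nM in this assay, at which 1 of the 3 values shown sits, and the limit of > 8860 nM in this assay, at which 1 of the 3 values shown sits, show. Compound 3 therefore stands nowhere in particular within the set: its value is a limit, and so are the two others. Among the measured compounds shown here, the one step between compounds that differ in a single place, a step that the two limits leave unreadable from compound 1 to compound 2, cannot be read, since both of its ends are limits.

Compound 4 `Cc1ccc2c(NCc3ccc(NC(=O)C4CCN(C(=O)OC(C)(C)C)CC4)cc3)nc(N(C)C)nc2c1` differs from compound 3 by tert-butoxycarbonyl in place of (piperidin-4-yl)methyl on an amine nitrogen in a ring. No measured step bears on this change: the only step shown concerns a different position and is itself unreadable. With compound 3 at a limit and nothing in the shown numbers pointing to a gain, the step that the limit leaves unreadable from compound 3 to compound 4 is expected to stay within the scatter. Compound 4 is estimated to give about 12000 nM, with a range from 5000 nM to 30000 nM, and most likely only a limit once more.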

Compound 4, half-maximal inhibitory concentration: > 4820 nM
Compound 4 was reported as a limit (the forecaster's own chance of this, stated with the estimate: 75%); the middle value is on the limit's open side.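

In this assay compound 4 gives > 4820 nM, which is a limit of the assay. Compound 3 and compound 4 thus both stand at limits, and no step can be read between them. The compounds shown leave open whether tert-butoxycarbonyl in place of (piperidin-4-yl)methyl changes the read-out at all, and at what concentration any of the four compounds reaches half-maximal inhibition.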